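Replacing Benzyl with 4-Methylphenyl on the Shared Core

This account rests on a few compounds, and the source may have more. Where it says the series, first, only, none or still open, it means among the compounds named here.

Compound 1 `CCOc1ccc(-c2nn3cc(-c4cccc(N)c4)nc3s2)cc1` gives >= 250000 nM in a functional assay on FM3A cells (Mus musculus) for inhibition, read by cell counting, with a stated time of 2 days (on this read-out lower numbers stand for stronger inhibition and higher numbers for weaker inhibition), a limit of the assay.
Compound 2 `Nc1cccc(-c2cn3nc(Cc4ccccc4)sc3n2)c1` gives 4700 nM.
Compound 3 `COc1cccc(Cc2nn3cc(-c4cccc(N)c4)nc3s2)c1` gives 10000 nM.

Among the measured compounds shown here, compound 2 stands at the lowest of the two numbers, with compound 3 nearest; the only measured step, a 2.1-fold higher number from compound 2 to compound 3 (0.33 log units; beyond the scatter), is modest. Compound 4 `Cc1ccc(-c2nn3cc(-c4cccc(N)c4)nc3s2)cc1` differs from compound 2 by 4-methylphenyl in place of benzyl on an aromatic carbon. For the measured compounds named here, no measured step covers this swap. Compound 1, in which an aromatic ring rather than a benzyl group sits on that carbon of the core, sits at the limit of >= 250000 nM in this assay, at which 1 of the 3 values shown sits. Compound 4 carries the same arrangement, so a large rise is expected, a 26-fold higher number from compound 2 to compound 4 (1.41 log units; beyond the scatter), with a fair chance that only a limit is reported. Compound 4 is estimated at 120000 nM, in the range 25000 nM to 300000 nM.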

Compound 4, half-maximal inhibitory concentration: 5800 nM
Estimate against measurement, compound 4: 21-fold (1.32 log units) above, outside the stated range (below it).
By their numbers in this assay, from the lowest: compounds 2, 4 and 3 (each within the scatter of the next, the first and the last beyond it). At a limit, above all of these: compound 1.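

With 4-methylphenyl in place of benzyl on this aromatic carbon of the shared core, this assay gives a 1.2-fold higher number from compound 2 to compound 4 (0.09 log units; within the scatter), so an aromatic ring on that carbon does not by itself bring the limit. What separates the two ring-bearing compounds is the group on that ring, with methyl in place of ethoxy giving an at least 43-fold lower number from compound 1 to compound 4 (1.63 log units; beyond the scatter). Compound 1 remains a limit of the assay: the limit of >= 250000 nM in this assay, at which 1 of the 4 values shown sits.

The compounds shown leave open whether a hydroxyl, an amine or a propoxy chain in place of that methyl would keep the value of compound 4 or reach the limit.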